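Removing a Methyl Group From an Inactive Urea

A few compounds are considered here, and "the series" means these few. Any claim that something is new, unique, unknown or untested is made for them only; others in the source may bear on it.

Compound 1 `O=C(Nc1cccc(-n2cc(-c3ccncc3)c(-c3ccc(Cl)c(O)c3)n2)c1)Nc1cccc(C(F)(F)F)c1` reaches only the limit > 32500 nM in a functional assay on SW-620 cells (Homo sapiens) for inhibition, read by sulforhodamine B assay, with a stated time of 48 h (a lower number here means that less compound is tolerated, a higher number that more compound is tolerated), so no number is known for it. Compound 2 `COc1cc(-c2nn(-c3cccc(NC(=O)Nc4ccc(Cl)c(Cl)c4)c3)cc2-c2ccncc2)ccc1Cl` likewise stops at the limit > 50000 nM in this assay. Compound 3 `O=C(Nc1cccc(-n2cc(-c3ccncc3)c(-c3ccc(Cl)c(O)c3)n2)c1)Nc1ccc(Cl)c(Cl)c1` differs from compound 2 by hydrogen in place of methyl on an oxygen on an aromatic ring. For the measured compounds named here, no measured step covers this change; what is known is that compound 1, which already carries the hydroxy, also sits at a limit (the limit of > 32500 nM in this assay, at which 1 of the 2 values shown sits), and compound 2 at a limit (the limit of > 50000 nM in this assay, at which 1 of the 2 values shown sits). The expected step that the limit leaves unreadable from compound 2 to compound 3 is none beyond the scatter. Compound 3 is expected at 60000 nM, between 30000 nM and 150000 nM.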

Compound 3, concentration lethal to 50% of the cells: > 32500 nM
Compound 3: only a limit was reported (the forecaster's own chance of this, stated with the estimate: 85%); the middle value lies beyond the limit too.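

For the compounds shown here, compounds 1, 2 and 3 all stop at limits rather than numbers, so no step between compound 3 and compound 1 or compound 2 can be read. Open, from the compounds shown here alone, is whether methoxy to hydroxy changes anything in this assay.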